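Bromo in place of methoxy: compound 1 to compound 3

The source may hold more compounds than are shown below. What is called first, only, known or untested is meant among the compounds shown, and "the series" means these compounds.

Among the compounds with values here, in a functional assay on HCT-116 cells (Homo sapiens) for inhibition, read by CCK-8 assay, with a stated time of 72 h, tested at 8 uM (a lower number here means less inhibition of growth, a higher number more inhibition of growth at the concentration tested), compound 1 (`COc1ccc(SCc2ccc(C(=O)Nc3ccccc3N)cc2)cc1`) gives 90.1%, the higher of the two numbers so far, and compound 2 (`Nc1ccccc1NC(=O)/C=C/c1ccc(CSc2ccc(C(F)(F)F)cn2)cc1`) gives 14.9%, a gap beyond the scatter. Within the data shown here, no measured pair differs in one place only, so no direct precedent exists. Compound 3 (`Nc1ccccc1NC(=O)c1ccc(CSc2ccc(Br)cc2)cc1`) carries bromo in place of methoxy on an aromatic carbon, para to a large group: bromo in place of methoxy on an aromatic carbon. Only a small fall, not beyond the scatter, is expected, an estimated a number 8.1 percentage points lower from compound 1 to compound 3 (within the scatter). For compound 3 the expected value is 82%, with an estimated range of 60% to 95%.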

Compound 3, percent growth inhibition at one concentration: 67.7%
Estimate against measurement, compound 3: 14.3 percentage points above; measured number inside the range.
By their numbers in this assay, from the lowest: compound 2; then compound 3; then compound 1.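

Within the data shown here, the change from 4-methoxyphenyl to 4-bromophenyl gives the first single-place step: in this assay it reads a number 22.4 percentage points lower from compound 1 to compound 3 (beyond the scatter), so this position, para to a large group, responds to the substituent. Even so, compound 3 keeps 67.7% in this read-out. Nothing on hand accounts for the step.

One step cannot separate the loss of methoxy from the gain of bromo. From the compounds shown here alone, how chloro, hydroxy or an amine would read at this position remains open.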